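The source may report more compounds than this note shows. Statements on the series, on what has been measured and on what is new or still open speak of the compounds shown alone.

For the measured compounds named here, in a functional assay on HEK293 cells for agonist activity at D(4) dopamine receptor (Homo sapiens), read by FLIPR (on this read-out higher numbers stand for larger maximal responses and lower numbers for smaller maximal responses), compound 1 `Cc1cc(C)cc(NC(=O)CN2CCC(c3cccc[n+]3[O-])CC2)c1` gives 76%, the higher of the two numbers measured so far. Going by the values given here, compound 2 `O=C(NCN1CCC(c2cccc[n+]2[O-])CC1)c1ccccn1` gives 40% in this assay, a reading that falls beyond the usual scatter below the one for compound 1. Compound 3 `O=C(CN1CCC(c2cccc[n+]2[O-])CC1)Nc1ccccc1F` has not yet been measured in this assay; it differs from compound 1 by 2-fluorophenyl in place of 3,5-dimethylphenyl on an amide-type nitrogen. Among the compounds with values here, no measured pair differing in a single place is available to size this swap, so only a modest fall is expected, a number 14 percentage points lower from compound 1 to compound 3 (beyond the scatter) in this assay. For compound 3 the estimated value in this assay is 62%, within a range from 35% to 88%.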

Compound 3, largest response reached (reported as efficacy), in percent of the reference or control that the assay uses: 63%
Estimate against measurement, compound 3: 1 percentage points below; the range from low to high includes it.
By their numbers in this assay, from the lowest: compound 2; then compound 3; then compound 1.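

For the compounds shown here, replacing 3,5-dimethylphenyl with 2-fluorophenyl on the amide-type nitrogen gives the first measured step at this position: in this assay, the result is a number 13 percentage points lower from compound 1 to compound 3 (beyond the scatter). The swap lowers the maximal response by a modest amount and does not abolish it. No available measurement gives a reason for this fall.

From the compounds shown here alone, the swap removes the two methyl groups and adds the fluorine in one move, so their separate contributions remain unknown. Going by these compounds, the reading for a plain phenyl or a methoxyphenyl group at this place also remains open.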